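Nitro Substitution on a Thiophene Pair, Measured and Expected

A few compounds are considered here, and "the series" means these few. Any claim that something is new, unique, unknown or untested is made for them only; others in the source may bear on it.

The study compares two small series built on related cores. Compound 1 `CCOC(=O)c1cc(-c2cc(OC)c(OC)c(OC)c2)c(-c2ccc(OC)cc2)s1` and compound 2 `CCOC(=O)c1cc(-c2cc(OC)c(OC)c(OC)c2)c(-c2ccc(OC)c([N+](=O)[O-])c2)s1` share one core, while compound 3 `COc1ccc(-c2cc(C(=O)O)sc2-c2cc(OC)c(OC)c(OC)c2)cc1` and compound 4 `COc1ccc(-c2cc(C(=O)O)sc2-c2cc(OC)c(OC)c(OC)c2)cc1[N+](=O)[O-]` share another; how the two cores differ is not broken down here. In a functional assay on HT-1080 cells (Homo sapiens) for antiproliferative activity, read by MTT assay, with a stated time of 72 h (on this read-out lower numbers stand for stronger inhibition and higher numbers for weaker inhibition), compound 1 gives 8370 nM. In this assay compound 2 gives 12700 nM. The change between them, (nitro in place of hydrogen on an aromatic carbon), produced a 1.5-fold higher number from compound 1 to compound 2 (0.18 log units; within the scatter). In this assay compound 3 gives 5810 nM, which sits within the scatter of compound 1 and is a lower number than that of compound 2.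

Compound 4 has not yet been measured. It differs from compound 3 by nitro in place of hydrogen on an aromatic carbon, the same change as that made from compound 1 to compound 2, set at the same place. Because a 1.5-fold higher number from compound 1 to compound 2 (0.18 log units; within the scatter) showed the change to sit within the scatter on the first core, compound 4 is expected to give a number close to that of compound 3, with a 1.5-fold higher number from compound 3 to compound 4 (0.18 log units; within the scatter) as the expected step. Compound 4 is therefore estimated at 8700 nM in this assay. Going by the values given here, the expected range for compound 4 runs from 4500 nM to 17000 nM, with the width reflecting that only one earlier example of this change is available.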

Compound 4, half-maximal inhibitory concentration: 38100 nM
Estimate against measurement, compound 4: 4.4-fold (0.64 log units) below; the measured number lies above the stated range.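

On the second core, nitro in place of hydrogen on an aromatic carbon, ortho to a methoxy group, gave a 6.6-fold higher number from compound 3 to compound 4 (0.82 log units; beyond the scatter) in this assay, so a step that lay within the scatter on the first core did not stay there on the second. The size of this change therefore did not carry from one core to the other in this pair of series: the same change on two cores in this assay, a 1.5-fold higher number (0.18 log units; within the scatter) from compound 1 to compound 2 and a 6.6-fold higher number (0.82 log units; beyond the scatter) from compound 3 to compound 4, 4.3-fold (0.64 log units) apart, beyond the scatter of two such steps This shows that a step read on one of these cores is a poor guide to the same step on the other, but with a single pair on each core it does not show which difference between the cores goes with the gap, why the two steps differ, or whether the gap would recur with any other change.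

The compounds shown leave open whether an amine, a nitrile or a fluorine atom at the same place would also give steps that differ between the two cores. They also leave open whether a nitro group at another place on this ring would do so, and whether the gap would hold with the methoxy group replaced by a longer chain.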